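Hydroxy to methyl on the aryl ring: cytotoxicity on Vero cells

A few compounds are considered here, and "the series" means these few. Any claim that something is new, unique, unknown or untested is made for them only; others in the source may bear on it.

Going by the values given here, compound 2 `O=C1CSC(c2ccc(O)cc2)N1CCN1CCCCC1` and compound 1 `COc1ccc(C2SCC(=O)N2CCN2CCCCC2)cc1` are the two measured members. Among the compounds with values here, in an ADME assay on Vero cells (Chlorocebus sabaeus) for cytotoxicity, read by neutral red uptake, tested at 98 ug/mL (on this read-out higher numbers stand for a weaker effect at the one concentration tested and lower numbers for a stronger effect), compound 2 gives 94%; in this assay compound 1 gives 89%, and the only measured step, a number 5 percentage points higher from compound 1 to compound 2 (within the scatter), sets compound 2 alongside compound 1 rather than apart from it. Compound 3 `Cc1ccc(C2SCC(=O)N2CCN2CCCCC2)cc1` is unmeasured; its change from compound 2 is methyl in place of hydroxy on an aromatic carbon. Within the data shown here, no measured step covers this exchange, but the single step on the same oxygen bears on it: a shift no larger than a number 6 percentage points lower from compound 2 to compound 3 (within the scatter) is expected in this assay, because a number 5 percentage points higher from compound 1 to compound 2 (within the scatter) already shows the oxygen substituent to matter little. Compound 3 is therefore estimated at 88%, within 74% to 98%.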

Compound 3, a percentage reported as activity, at one concentration (the size of the read-out at that concentration, not a potency): 100%
Beside the measured number, compound 3's estimate is 12 percentage points below it; the measured number lies above the stated range.
By their numbers in this assay, from the lowest: compounds 1, 2 and 3 (each within the scatter of the next, the first and the last beyond it).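

In this assay, methyl in place of hydroxy on the aromatic carbon gives a number 6 percentage points higher from compound 2 to compound 3 (within the scatter), so this exchange leaves compound 3 level with compound 2. Methyl in place of methoxy gives a number 11 percentage points higher from compound 1 to compound 3 (beyond the scatter), the first step at this position to pass the scatter, and a modest one. No measured property accounts for that separation. Open, as far as these compounds go, is whether chlorine or an amine at the same position would stay level with compound 3. Also open, from the compounds shown here alone, is whether a longer chain in place of the methyl would do so.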